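Swapping a Two-Ring Group for a Small Fluorinated Chain

The source may hold more compounds than are shown below. What is called first, only, known or untested is meant among the compounds shown, and "the series" means these compounds.

Compound 1 `COc1ccc(OCc2cc(C)nc(-c3ccccn3)n2)cc1`: 7940 nM
Compound 2 `CN(C)c1cc(COc2cccc(F)c2)nc(-c2ccccn2)n1`: 1580 nM
Compound 3 `Fc1ccc(OCc2cc(N3CC4(CCO4)C3)nc(-c3ccccn3)n2)c(F)c1F`: 501 nM

All three numbers come from a functional assay on cells for antagonist activity at Free fatty acid receptor 1 (Homo sapiens), read by TR-FRET and inositol phosphate accumulation, with a stated time of 2 h; a higher number here means a weaker inhibitor, a lower number a stronger inhibitor. Among them, compound 3 has the lowest number, and so is the strongest inhibitor of the set. The nearest to it is compound 2, whose number is higher by a margin beyond the usual scatter; compound 1 is furthest away, again beyond the scatter. The three compounds differ from one another in more than one place, so no single change among them can be read off on its own.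

Compound 4 `Fc1ccc(OCc2cc(OCC(F)(F)F)nc(-c3ccccn3)n2)c(F)c1F` differs from compound 3 in one place only: a group of 6 heavy atoms (2 carbon, 1 oxygen, 3 fluorine; no ring) in place of a group of 7 heavy atoms (5 carbon, 1 nitrogen, 1 oxygen; 2 four-membered non-aromatic rings with 1 hetero atom each), on an aromatic carbon. In words, a trifluoroethoxy chain takes the place of the two-ring group, on the same aromatic carbon of the shared core, next to the ring nitrogen and meta to the pyridin-2-yl group.

Going by the values given here, no measured pair shows what such a swap does here, so the expectation rests on compound 3 alone. A modest move toward a higher number, with a fair chance of staying within the scatter, seems the most likely outcome.

Compound 4 is therefore expected to give about 900 nM, within a range of 250 nM to 3200 nM. That expected value corresponds to an estimated step of a 1.8-fold higher number from compound 3 to compound 4 (0.25 log units; within the scatter).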

Compound 4, half-maximal inhibitory concentration: 7.94 nM
Compound 4: middle estimate off by 110-fold (2.05 log units), on the high side; the whole stated range lies above it.
By their numbers in this assay, from the lowest: compound 4; then compound 3; then compound 2; then compound 1.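

In this assay, the swap on this aromatic carbon gives a 63-fold lower number from compound 3 to compound 4 (1.80 log units; beyond the scatter). Going by these compounds alone, this is the first comparison in the set in which only one place changes, so it shows that the group next to the ring nitrogen and meta to the pyridin-2-yl group can by itself shift the number by a large amount, a point that the earlier compounds, which differ in more than one place, could not settle. No accompanying measurement bears on why the 2,2,2-trifluoroethoxy group gives the lower number, so the step stands as an observation only.

A single pair cannot separate the contribution of the oxygen from that of the fluorine atoms, or show whether losing the two-ring group matters as much as gaining the new chain; a plain ethoxy chain, a longer fluorinated chain such as 3,3,3-trifluoropropoxy, or a small amine such as methylamino on the same carbon would help to separate these. Going by these compounds, it also remains open whether a similar step would appear with the other ring substitution patterns seen in compound 1 and compound 2.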